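Swapping an aromatic ring on a piperidine in a dopamine assay

The source may report more compounds than this note shows. Statements on the series, on what has been measured and on what is new or still open speak of the compounds shown alone.

Measured compounds:
- compound 1 `Cc1cccc(NC(=O)CCN2CCN(c3ccccn3)CC2)c1`: 612 nM
- compound 2 `Cc1ccc(C2CCN(CC(=O)Nc3cccc(C)c3)CC2)nc1`: "not active" (no number reported)
- compound 3 `O=C(CN1CCN(c2ccc(Cl)cn2)CC1)Nc1cccnc1`: "not active" (no number reported)

All three were tested in a functional assay on cells for agonist activity at D(4) dopamine receptor (Homo sapiens), read by TR-FRET and cAMP accumulation, with a stated time of 30 min; on this read-out higher numbers stand for an effect only at larger amounts of compound and lower numbers for an effect already at smaller amounts. Compound 1 gives a measurable number there, 612 nM. Compound 2 stands apart: in this assay compound 2 is recorded as "not active" (no number reported), with no number attached, so there is no value to compare it against. Compound 3 is in the same position, reported in this assay as "not active" (no number reported).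

The next compound is compound 4 `Cc1cccc(NC(=O)CN2CCC(c3ccc(Cl)cc3)CC2)c1`. It is derived from compound 2 by one change: 4-chlorophenyl in place of 5-methylpyridin-2-yl on a saturated ring carbon. Going by the values given here, since compound 2 has no number, no step between measured compounds can be drawn, and any expectation rests on compound 1 alone, whose value in this assay is 612 nM. Among the compounds with values here, because compound 2 is recorded as "not active" (no number reported), the only movement open to compound 4 is toward an effect appearing; how far is a guess. Compound 4 is estimated at 400 nM, within a range from 40 nM to 4000 nM.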

Compound 4, half-maximal effective concentration: "not active" (no number reported)
Compound 4: no number reported, and the estimate cannot be compared.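

Compound 2 and compound 4 are both recorded as not active, with no number, so no step can be read between them, and no measured evidence bears on this result. The compounds shown leave open whether any group on that saturated ring carbon would give a measurable effect.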